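This account rests on a few compounds, and the source may have more. Where it says the series, first, only, none or still open, it means among the compounds named here.

In a functional assay on L5178Y cells (Mus musculus) for antiproliferative activity (a lower number here means a stronger inhibitor, a higher number a weaker inhibitor), the three measured compounds stand as follows.
Compound 1 `Cc1ccc(S(=O)(=O)O[C@@H]2[C@@H](O)[C@H](n3ccc(N)nc3=O)O[C@@H]2CO)cc1`: > 100 ug/mL, a limit of the assay.
Compound 2 `CS(=O)(=O)O[C@@H]1[C@@H](O)[C@H](n2cc(F)c(N)nc2=O)O[C@@H]1CO`: 5.3 ug/mL.
Compound 3 `CS(=O)(=O)O[C@@H]1[C@@H](O)[C@H](n2ccc(N)nc2=O)O[C@@H]1CO`: > 100 ug/mL, a limit of the assay.

Compound 3 thus sits at the limit of this assay, and only compound 2 gives a number. Within the data shown here, the step of an at least 18-fold higher number from compound 2 to compound 3 (1.27 log units; beyond the scatter) is the one readable step, while the step that the two limits leave unreadable from compound 1 to compound 3 cannot be sized, since both of its ends are limits, as the line the limit of > 100 ug/mL in this assay, at which 2 of the 3 values shown sit, records.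

Compound 4 `Nc1ccn([C@@H]2O[C@H](CO)[C@H](F)[C@H]2O)c(=O)n1` differs from compound 3 at a single place: fluoro in place of (methylsulfonyl)oxy on a saturated ring carbon. Among the measured compounds shown here, no measured step touches this place. The step from compound 2 to compound 3 concerns a fluoro on an aromatic carbon, not on a saturated ring carbon, and the step from compound 1 to compound 3 changes the group on the sulfonyl sulfur rather than removing it. Whether the change in this assay moves compound 4 to a stronger or weaker inhibition therefore cannot be read from the shown steps, and since compound 3 is a limit, even the size of any move is open. The estimate for compound 4 is therefore wide: 40 ug/mL, between 5 ug/mL and 100 ug/mL, which as a step means an expected at least 2.5-fold lower number from compound 3 to compound 4 (0.39 log units; beyond the scatter).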

Compound 4, concentration for 50% inhibition: > 100 ug/mL
Compound 4 was reported as a limit; the forecaster's own chance of this, stated with the estimate: 50%; at least 2.5-fold (0.39 log units) between middle value and limit.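

In this assay compound 4 gives > 100 ug/mL, a limit of the assay. Among these compounds, no step from compound 3 to compound 4 can be read, since both ends are limits: the limit of > 100 ug/mL in this assay, at which 3 of the 4 values shown sit. The compounds shown leave open whether fluoro in place of (methylsulfonyl)oxy on a saturated ring carbon changes the inhibition at all, and in which direction.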